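One measured compound and one exchanged group

The source may hold more compounds than are shown below. What is called first, only, known or untested is meant among the compounds shown, and "the series" means these compounds.

Among the measured compounds shown here, only one firm number anchors this small set. In an ADME assay on J774.A1 cells (Mus musculus) for cytotoxicity, read by MTT assay, with a stated time of 48 h (a higher number here means that more compound is tolerated, a lower number that less compound is tolerated), compound 1 `COC(=O)c1c([N+](=O)[O-])noc1-c1ccccc1` gives "not determined" (no result reported), and compound 2 `COC(=O)c1c([N+](=O)[O-])noc1-c1ccc(F)cc1` gives "not determined" (no result reported). Compound 3 `COC(=O)c1c(NCCNc2ccnc3cc(Cl)ccc23)noc1-c1ccc([N+](=O)[O-])cc1` gives 3790 nM. For the measured compounds named here, that is the only number available, and there is nothing to rank it against, neither as high nor as low.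

Compound 4 `COC(=O)c1c(NCCNc2ccnc3cc(Cl)ccc23)noc1-c1ccccc1F` is still to be measured in this assay. It keeps most of the structure of compound 3 and exchanges a single group 2-fluorophenyl in place of 4-nitrophenyl on an aromatic carbon. That carbon lies next to the ring oxygen and next to the ring atom that bears a methoxycarbonyl group.

Going by the values given here, no measured pair here shows what such an exchange does, and the only guide is compound 3 at 3790 nM. The expected change is a 1.3-fold higher number from compound 3 to compound 4 (0.12 log units; within the scatter), a small move towards more compound being tolerated that is not expected to stand clear of the usual scatter. Compound 4 is estimated at 5000 nM, with an expected range from 2000 nM to 12000 nM.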

Compound 4, half-maximal cytotoxic concentration: 3420 nM
Beside the measured number, compound 4's estimate is 1.5-fold (0.16 log units) above it, and the stated range covers the measured number.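

With compound 4 measured, this position has its first pair that differs in one place. In this assay the exchange gives a 1.1-fold lower number from compound 3 to compound 4 (0.04 log units; within the scatter), so the two compounds cannot be told apart in how much of each the cells tolerate. This single pair shows that, in this one setting, 2-fluorophenyl can stand in place of 4-nitrophenyl on the aromatic carbon next to the ring oxygen without a change that stands clear of the scatter, even though the hydrogen-bond acceptors counted on 4-nitrophenyl are absent from the entering group, and nothing measured here gives a reason for this result.

The compounds shown leave open whether a 4-methoxyphenyl group or a simple amine on this same carbon would also stay within the scatter of these two compounds or would move the number clear of it. Also open, from the compounds shown here alone, is what a carboxylic acid in place of the methoxycarbonyl group would do, and compound 1 and compound 2, which carry no number, offer no comparison on either question.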